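Fluoro for cyano on the sulfonyl aryl ring

This account rests on a few compounds, and the source may have more. Where it says the series, first, only, none or still open, it means among the compounds named here.

Within the data shown here, compound 2 `CC1CCN(c2c(S(=O)(=O)c3ccc(C#N)cc3)cnc3c(F)cccc23)CC1` stands highest of the two numbers so far in an assay on isolated protein for displacement of a labelled ligand from metabotropic glutamate receptor 5 (Homo sapiens), with a stated time of 60 min, tested at 1 uM (a higher number here means more inhibition at the concentration tested (going by the name of the read-out), a lower number less inhibition), giving 86%, against compound 1 `CC1CCN(c2c(S(=O)(=O)c3ccccc3)cnc3c(F)cccc23)CC1`, which in this assay gives 13%. Among the measured compounds shown here, the one measured step, a number 73 percentage points higher from compound 1 to compound 2 (beyond the scatter), came with cyano in place of hydrogen on an aromatic carbon. Compound 3 `CC1CCN(c2c(S(=O)(=O)c3ccc(F)cc3)cnc3c(F)cccc23)CC1` has not yet been measured; it differs from compound 2 by fluoro in place of cyano on an aromatic carbon, on an aromatic carbon of a six-membered aromatic ring of carbon only, para to a large group. For the measured compounds named here, the step from compound 1 to compound 2 bears on this change only in part: it shows what the cyano group added, and compound 3 gives that group up, yet no measured step shows fluoro against hydrogen or against cyano on this ring. Removing the cyano is expected to cost inhibition, so a downward step is expected, a number 46 percentage points lower from compound 2 to compound 3 (beyond the scatter), with compound 3 estimated at 40%, within 15% to 70%.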

Compound 3, a percentage reported as inhibition, at one concentration (the size of the read-out at that concentration, not a potency): 26%
Compound 3: the middle estimate sits 14 percentage points above what was measured, within the range that was stated.
By their numbers in this assay, from the lowest: compound 1; then compound 3; then compound 2.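

In this assay, fluoro does not stand in for cyano at this place on the aromatic ring, para to a large group: a number 60 percentage points lower from compound 2 to compound 3 (beyond the scatter), so most of the gain that came with cyano is not kept. Fluoro against hydrogen can now be read as well, a number 13 percentage points higher from compound 1 to compound 3 (beyond the scatter), which puts the three groups in the order hydrogen, fluoro, cyano at this place, with only cyano giving a large step from hydrogen. Nothing available accounts for the gap between fluoro and cyano.

Going by these compounds, whether the high inhibition depends on the nitrile itself or would also come with a primary amide, a carboxylic acid or a methyl ester at this place stays open. Also open, on these data alone, is whether the same order holds once the shared core is changed, and how these single-concentration readings translate into potency.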